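Amide-to-aryl swap on a pyrazole series in colon cancer cells

The source may hold more compounds than are shown below. What is called first, only, known or untested is meant among the compounds shown, and "the series" means these compounds.

Compound 1 `COc1cc(Cl)cc(-c2nn(-c3cccc(NC(=O)c4ccc(Cl)c(Cl)c4)c3)cc2-c2ccncc2)c1`: 57.9%
Compound 2 `COc1cc(Cl)cc(-c2nn(-c3cccc(NC(=O)Nc4ccc(Cl)c(C(F)(F)F)c4)c3)cc2-c2ccncc2)c1`: 7.28%
Compound 3 `COc1cc(Cl)cc(-c2nn(-c3cccc(NC(=O)Nc4cc(C(F)(F)F)cc(C(F)(F)F)c4)c3)cc2-c2ccncc2)c1`: 6.21%

In a functional assay on HCT-15 cells (Homo sapiens) for inhibition, read by sulforhodamine B assay, with a stated time of 48 h, tested at 10 uM (a higher number here means a weaker effect of the compound at the concentration tested, a lower number a stronger effect), compound 1 gives 57.9%, the highest of the three numbers, so it shows the weakest effect; compound 2 lies far below it, and compound 3 further still. The unmeasured compound 4 `COc1cc(Cl)cc(-c2nn(-c3cccc(NC(=O)c4cccc(C(F)(F)F)c4)c3)cc2-c2ccncc2)c1` differs from compound 1 in one place: 3-(trifluoromethyl)phenyl in place of 3,4-dichlorophenyl on a carbonyl carbon. Among the measured compounds shown here, the only measured step that bears on it is a number 50.6 percentage points lower from compound 1 to compound 2 (beyond the scatter), but that step also exchanges the amide for a urea, so it speaks only partly to this change. With the amide kept, a step of modest size is expected, a number 7.9 percentage points lower from compound 1 to compound 4 (within the scatter). Compound 4 is therefore estimated at 50%, within 25% to 80%.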

Compound 4, a percentage reported as activity, at one concentration (the size of the read-out at that concentration, not a potency): 33.2%
Compound 4: middle estimate off by 16.8 percentage points, on the high side; the range from low to high includes it.
By their numbers in this assay, from the lowest: compounds 3 and 2 (each within the scatter of the next); then compound 4; then compound 1.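

In this assay, among the compounds shown here, the change to 3-(trifluoromethyl)phenyl on a carbonyl carbon gives a number 24.7 percentage points lower from compound 1 to compound 4 (beyond the scatter) with the amide kept, so the aryl group alone moves the read-out, which the earlier compounds could not show. Compound 4 still does not reach the urea, with a number 25.9 percentage points higher from compound 2 to compound 4 (beyond the scatter) in a step that alters both the amino link and the chlorine. Nothing available explains either step.

On these data alone, it remains open how a urea bearing 3-(trifluoromethyl)phenyl would compare, and how the amide would respond to a nitrile in place of trifluoromethyl.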